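The compounds below may be only part of what the source reports. "The series", "measured", "known", "first", "only" and "open" are said of these compounds alone.

Compound 1 `O=C(NC1CCN(Cc2ccccc2)CC1)c1coc2ccccc2c1=O` is the reference point of this small set. Among the compounds with values here, in an assay on isolated protein for inhibition of Amine oxidase [flavin-containing] B (Homo sapiens), read by fluorescence and Amplex Red, with stated times of 15 min and 20 min (on this read-out lower numbers stand for stronger inhibition and higher numbers for weaker inhibition), compound 1 gives 17700 nM, the lowest of the two numbers recorded, and the only neighbour is compound 2 `O=C(NC1CCN(Cc2ccccc2)CC1)c1coc2ccc(Br)cc2c1=O`, which in this assay gives 22800 nM. Within the data shown here, the one measured step, bromo in place of hydrogen on an aromatic carbon, runs a 1.3-fold higher number from compound 1 to compound 2 (0.11 log units; within the scatter), so the two compounds cannot be told apart on this read-out.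

Compound 3 `O=C(NC1CCN(Cc2ccccc2)CC1)c1coc2cc(Br)ccc2c1=O` has not yet been measured. It differs from compound 1 by bromo in place of hydrogen on an aromatic carbon of the shared core, here on the six-membered carbon ring of the fused system, meta to a fused ring and para to a fused ring. Among the measured compounds shown here, the only guide is the step from compound 1 to compound 2, which was within the scatter. The same kind of addition at a different carbon of the same ring is therefore expected to move the number little, if at all, and the estimated step is a 1.1-fold higher number from compound 1 to compound 3 (0.05 log units; within the scatter). Compound 3 is accordingly expected to give about 20000 nM in this assay, with a likely range from 9000 nM to 45000 nM.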

Compound 3, half-maximal inhibitory concentration: 19700 nM
Estimate against measurement, compound 3: 1.0-fold (0.01 log units) above; measured number inside the range.
By their numbers in this assay, from the lowest: compounds 1, 3 and 2 (each within the scatter of the next).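

In this assay, bromo in place of hydrogen on the aromatic carbon meta to a fused ring and para to a fused ring gives a 1.1-fold higher number from compound 1 to compound 3 (0.05 log units; within the scatter) and so cannot be told apart from the unsubstituted compound on this read-out. The earlier pair had shown this for only one carbon, whereas compound 2 and compound 3 now show that bromo at either of two carbons of the six-membered aromatic ring stays within the scatter of compound 1, and the two bromo compounds also lie within the scatter of each other. Nothing available explains why the number stays put at either carbon.

These compounds test only bromo, so they leave open whether a methoxy group or an amine at these same carbons would shift the number beyond the scatter. With the rest of the structure the same in all three, they also leave open whether a carboxylic acid or a longer chain elsewhere on the shared core would move the number away from the level these compounds share.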